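This account rests on a few compounds, and the source may have more. Where it says the series, first, only, none or still open, it means among the compounds named here.

Working notes on a small set of chloromethylbenzyl purines.

Compound 1 `ClCc1ccc(Cn2cnc3c(Cl)ncnc32)cc1` carries an unsubstituted core. In a functional assay on CCRF-CEM cells (Homo sapiens) for cytotoxicity, read by sulforhodamine B assay, with a stated time of 48 h (a higher number here means a weaker inhibitor of growth, a lower number a stronger inhibitor of growth), compound 1 gives only a limit of the assay, > 100000 nM. Compound 2 `Nc1nc(Cl)c2ncn(Cc3ccc(CCl)cc3)c2n1` differs from it by a single change, (amino in place of hydrogen on an aromatic carbon). In this assay compound 2 likewise gives only a limit, > 100000 nM. The step that the two limits leave unreadable from compound 1 to compound 2 therefore cannot be read in size, since it rests on (the limit of > 100000 nM in this assay, at which 2 of the 3 values shown sit).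

Compound 3 `ClCc1ccccc1Cn1cnc2c(Cl)ncnc21` has the same atoms as compound 1 joined differently; the difference between the two cores is not broken down here. In this assay, going by the values given here, compound 3 gives 3230 nM, the only number among the three measured values.

Compound 4 `Nc1nc(Cl)c2ncn(Cc3ccccc3CCl)c2n1` is not yet measured. It differs from compound 3 by amino in place of hydrogen on an aromatic carbon, the same change as from compound 1 to compound 2, at the same place. Since that earlier step is unreadable, the step to compound 4 is estimated without a measured precedent: a 1.9-fold higher number from compound 3 to compound 4 (0.27 log units; within the scatter) is expected, resting only on compound 3 at 3230 nM as the anchor. Compound 4 is thus expected at about 6000 nM, with a range from 1200 nM to 60000 nM.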

Compound 4, concentration for total growth inhibition: > 100000 nM
Compound 4: only a limit was reported; the forecaster's own chance of this, stated with the estimate: 20%; at least 16-fold (1.22 log units) between middle value and limit.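

In this assay, amino in place of hydrogen on an aromatic carbon of the core of compound 3 gives an at least 30-fold higher number from compound 3 to compound 4 (1.49 log units; beyond the scatter), so on this core the change goes with a large loss of growth inhibition. Compound 4 gives only a limit of the assay, > 100000 nM, so this step has a lower bound and no measured size. Whether the change acts alike on both cores is not shown, since the step on the core of compound 1 cannot be read and no two sizes can be compared, so the result on one core does not establish a general effect of amino across the series: the limit of > 100000 nM in this assay, at which 3 of the 4 values shown sit.

Open, from the compounds shown here alone, is whether a different group on that same aromatic carbon, such as methylamino, dimethylamino or methoxy, would keep the growth inhibition seen for compound 3. Also open, going by these compounds, is how the core of compound 3 responds to other changes, such as a hydroxymethyl group in place of the chloromethyl group.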